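Replacing a piperidinylmethyl group with a cyclopropylcarbamoyl group

The source may report more compounds than this note shows. Statements on the series, on what has been measured and on what is new or still open speak of the compounds shown alone.

The shared core of compound 1 `Cn1ncc(Cl)c1-c1cc(C(=O)N[C@@H]2CN[C@H](CCO)C[C@H]2c2ccc(F)c(F)c2)oc1Cl` is tested in a functional assay on LNCaP cells (Homo sapiens) for antiproliferative activity; a lower number here means a stronger inhibitor, a higher number a weaker inhibitor. Compound 1 gives 60 nM. Compound 2 `Cn1ncc(Cl)c1-c1cc(C(=O)N[C@@H]2CN[C@H](CCN3CCCCC3)C[C@H]2c2ccc(Cl)c(Cl)c2)oc1Cl` gives 1780 nM in this assay, the higher of the two numbers and beyond the scatter from compound 1. Compound 3 `Cn1ncc(Cl)c1-c1cc(C(=O)N[C@@H]2CN[C@H](CC(=O)NC3CC3)C[C@H]2c2ccc(Cl)c(Cl)c2)oc1Cl` differs from compound 2 by one change: cyclopropylcarbamoyl in place of (piperidin-1-yl)methyl on a saturated chain carbon bound to a saturated ring carbon. Compound 1 shows that a neutral group carrying a hydrogen-bond donor at this chain position goes with a low number, so compound 3 is expected to move by a 4.5-fold lower number from compound 2 to compound 3 (0.65 log units; beyond the scatter) toward a lower value. Compound 3 is estimated at 400 nM, within 100 nM to 1500 nM.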

Compound 3, half-maximal inhibitory concentration: 190 nM
Beside the measured number, compound 3's estimate is 2.1-fold (0.32 log units) above it, within the range that was stated.
By their numbers in this assay, from the lowest: compound 1; then compound 3; then compound 2.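

In this assay, among the compounds shown here, cyclopropylcarbamoyl in place of (piperidin-1-yl)methyl on a saturated chain carbon bound to a saturated ring carbon gives a 9.4-fold lower number from compound 2 to compound 3 (0.97 log units; beyond the scatter) and is the first change read at this position with all else held the same. For the compounds shown here, compound 1 differs from compound 2 in more than one place, so only this step isolates the chain. No measurement available explains the step.

From the compounds shown here alone, whether the amide hydrogen, the carbonyl or the cyclopropyl ring carries the change remains open. A carboxylic acid, a simple methyl amide or a longer chain at this place would begin to separate these.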